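Replacing a Benzyl Sulfonamide with a Morpholine Sulfonamide

The source may report more compounds than this note shows. Statements on the series, on what has been measured and on what is new or still open speak of the compounds shown alone.

Compound 2 `CC1(C)C=C(n2ccccc2=O)c2cc(S(=O)(=O)NCc3ccccc3)ccc2O1` carries a benzylamino group on its sulfonyl sulfur. In a functional assay on the whole organism (aorta) with Rattus norvegicus as the target (on this read-out higher numbers stand for larger maximal responses and lower numbers for smaller maximal responses), compound 2 gives 71.1%, the lower of the two single numbers available. Among the compounds with values here, its nearest neighbour is compound 1 `CC1(C)C=C(n2ccccc2=O)c2cc(S(=O)(=O)NCCO)ccc2O1`, which in this assay gives 95.5%; the change a number 24.4 percentage points lower from compound 1 to compound 2 (beyond the scatter) is the only step between two singly measured compounds here. Compound 3 `CC1(C)C=C(n2ccccc2=O)c2cc(S(=O)(=O)Nc3ccccc3)ccc2O1` has been measured twice in this assay, giving 63.6%; 82.5% (2 entries), and the spread between those two entries (the several entries of compound 3 in this assay, 63.6%; 82.5% (2 entries)) shows how far repeated measurements of one compound can drift apart.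

Compound 4 `CC1(C)C=C(n2ccccc2=O)c2cc(S(=O)(=O)N3CCOCC3)ccc2O1` differs from compound 2 at the sulfonyl sulfur: morpholin-4-yl in place of benzylamino on a sulfonyl sulfur. Within the data shown here, no measured step alters this position in the same way, so the only guide is that enlarging the group on the sulfonamide from hydroxymethyl to phenyl lowered the maximal response modestly, while a phenyl bound directly to the nitrogen in compound 3 gave values on both sides of compound 2. Compound 4 is therefore expected to stay near compound 2, with a step of a number 4.9 percentage points higher from compound 2 to compound 4 (within the scatter) that is within or only just beyond the scatter. The estimate for compound 4 in this assay is 76%, within a range from 58% to 94%.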

Compound 4, largest response reached (Emax), in percent of the reference or control that the assay uses: 75.5%
Compound 4: the middle estimate sits 0.5 percentage points above what was measured; measured number inside the range.
By their numbers in this assay, from the lowest: compounds 2 and 4 (each within the scatter of the next); then compound 1.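

Within the data shown here, compounds 1, 2 and 3 all keep a hydrogen on the sulfonamide nitrogen, so compound 4 is the first here in which that nitrogen sits in a ring, with morpholin-4-yl counting 0 hydrogen-bond donors where benzylamino counts 1. In this assay, that exchange, which also removes the aromatic ring, leaves the result indistinguishable from the benzylamino compound, with a number 4.4 percentage points higher from compound 2 to compound 4 (within the scatter), so neither the amide hydrogen nor the aromatic ring is needed to hold this level of response. The (2-hydroxyethyl)amino group of compound 1 remains apart, with a number 20 percentage points lower from compound 1 to compound 4 (beyond the scatter), although even these gaps deserve caution given how widely repeat entries of a single compound can differ: the several entries of compound 3 in this assay, 63.6%; 82.5% (2 entries)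

The compounds shown leave open whether the ring oxygen of morpholin-4-yl has any part in the result, which a piperidin-1-yl group, with carbon in its place, would test. They also leave open whether the higher number of compound 1 depends on its hydroxyl group, which a plain ethylamino chain would help to settle.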